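Taking one methyl off a saturated-chain compound

A few compounds are considered here, and "the series" means these few. Any claim that something is new, unique, unknown or untested is made for them only; others in the source may bear on it.

In a functional assay on MDA-MB-231 cells (Homo sapiens) for antiproliferative activity, read by MTT assay (a lower number here means a stronger inhibitor, a higher number a weaker inhibitor), compound 3 (`CCCCCCCCCCCCCCCc1cc(=O)c2c(O)c(C)c(O)c(C)c2o1`) reaches only a limit of > 87000 nM and gives no number. Compound 4 (`CCCCCCCCCCCCCCCc1cc(=O)c2c(O)c(C)c(O)cc2o1`) carries hydrogen in place of methyl on an aromatic carbon. Among the compounds with values here, no measured step covers this change directly. Two relatives with hydrogen at that carbon but with unsaturated chains do give numbers: compound 1 (`CC/C=C\C/C=C\C/C=C\CCCCCCCc1cc(=O)c2c(O)c(C)c(O)cc2o1`) reads 6790 nM and compound 2 (`CCCCC/C=C\C/C=C\CCCCCCCc1cc(=O)c2c(O)c(C)c(O)cc2o1`) reads 16100 nM in this assay. Butyl in place of but-1-en-1-yl gave a 2.4-fold higher number from compound 1 to compound 2 (0.37 log units; beyond the scatter) and the chain of compound 4 is fully saturated, so it should read somewhat higher than compound 2 yet still give a number. A sizeable step towards a lower number is expected (an at least 2.9-fold lower number from compound 3 to compound 4 (0.46 log units; beyond the scatter)). Compound 4 is estimated at 30000 nM (range 13000 nM to 80000 nM).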

Compound 4, half-maximal inhibitory concentration: 42800 nM
Beside the measured number, compound 4's estimate is 1.4-fold (0.15 log units) below it; low and high end bracket the measured number.
By their numbers in this assay, from the lowest: compound 1; then compound 2; then compound 4. At a limit, above all of these: compound 3.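

Compound 3 gives only a limit, not a number: the limit of > 87000 nM in this assay, at which 1 of the 4 values shown sits. From the compounds shown here alone, with hydrogen in place of methyl on this aromatic carbon, this assay shows an at least 2.0-fold lower number from compound 3 to compound 4 (0.30 log units; that floor lies within the scatter), and the true size of this step remains unknown. Among the compounds with hydrogen there, the saturated chain gives the highest number, with a 2.7-fold higher number from compound 2 to compound 4 (0.42 log units; beyond the scatter) and a 6.3-fold higher number from compound 1 to compound 4 (0.80 log units; beyond the scatter).

The compounds shown leave open how a chlorine or an amine on this aromatic carbon would read. They also leave open how a shorter saturated chain would read.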